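The source may hold more compounds than are shown below. What is called first, only, known or untested is meant among the compounds shown, and "the series" means these compounds.

Compound 1 `Cn1ccc(-c2cccc3c2CCC3c2ncc[nH]2)n1` is measured in a functional assay on CHO cells for agonist activity at Alpha-1A adrenergic receptor (Homo sapiens), read by FLIPR and calcium flux (on this read-out higher numbers stand for larger maximal responses and lower numbers for smaller maximal responses), where compound 1 gives 19%. This is the lowest of the three numbers recorded in this assay. Compound 3 `Clc1ccc2c(c1-c1ccn[nH]1)CCC2c1ncc[nH]1` gives 40% in this assay, a higher number that stands beyond the usual scatter from compound 1. Compound 2 `CS(=O)(=O)Nc1c(Cl)ccc2c1CCCC2c1ncc[nH]1` gives 61% in this assay, the highest of the three and again beyond the scatter from compound 1.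

Compound 4 `c1cc(-c2ncco2)c2c(c1)C(c1ncc[nH]1)CC2` is not yet measured. It differs from compound 1 in one place: 1,3-oxazol-2-yl in place of 1-methyl-1H-pyrazol-3-yl on an aromatic carbon. One five-membered aromatic ring with two hetero atoms thus gives way to another five-membered aromatic ring with two hetero atoms on the same aromatic carbon of the shared core. Within the data shown here, no measured pair shows this exchange, so its effect in this assay is unknown. A small step from compound 1 to compound 4 is expected, not clearly beyond the scatter, a number 6 percentage points higher from compound 1 to compound 4 (within the scatter). Compound 4 is therefore estimated at 25%, within a range from 10% to 45%.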

Compound 4, largest response reached (Emax), in percent of the reference or control that the assay uses: 63%
The estimate for compound 4 lay 38 percentage points below the measured number; the measured number lies above the stated range.
By their numbers in this assay, from the lowest: compound 1; then compound 3; then compounds 2 and 4 (each within the scatter of the next).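

In this assay the exchange of 1-methyl-1H-pyrazol-3-yl for 1,3-oxazol-2-yl on this aromatic carbon gives a number 44 percentage points higher from compound 1 to compound 4 (beyond the scatter), which shows that the read-out at this position depends strongly on which five-membered aromatic ring is attached. The two groups have the same counts of hydrogen-bond donors and acceptors, carry no net charge and each has 2 hetero atoms in its ring, so these counts alone do not separate them. Nothing available accounts for the size of this step.

The compounds shown leave open whether a 1,3-thiazol-2-yl group or a plain phenyl ring on this carbon would give a number like that of compound 4. They also leave open whether the same exchange would give a step of similar size on a core that carries chlorine.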